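From 2-bromobenzyl to 4-methylbenzyl: compound 3 to compound 4

A few compounds are considered here, and "the series" means these few. Any claim that something is new, unique, unknown or untested is made for them only; others in the source may bear on it.

Going by the values given here, in a functional assay on MCF cells (Homo sapiens) for antiproliferative activity, with a stated time of 72 h (on this read-out lower numbers stand for stronger inhibition and higher numbers for weaker inhibition), compound 1 `OC[C@H]1O[C@@H](n2cnc3c(NCc4ccc(F)cc4)ncnc32)[C@H](O)[C@@H]1O` gives 21000 nM, the only actual number so far. Compound 2 `OC[C@H]1O[C@@H](n2cnc3c(NCc4ccccc4Cl)ncnc32)[C@H](O)[C@@H]1O` reads > 166000 nM, which is a limit of the assay. Compound 3 `OC[C@H]1O[C@@H](n2cnc3c(NCc4ccccc4Br)ncnc32)[C@H](O)[C@@H]1O` reads > 166000 nM, which is also a limit and not a number. The series therefore stands with the limit of > 166000 nM in this assay, at which 2 of the 3 values shown sit.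

Compound 4 `Cc1ccc(CNc2ncnc3c2ncn3[C@@H]2O[C@H](CO)[C@@H](O)[C@H]2O)cc1` carries 4-methylphenyl in place of 2-bromophenyl on a saturated chain carbon bound to a nitrogen on an aromatic ring.

Among the compounds with values here, no measured step covers this change directly. The nearest evidence is an at least 7.9-fold higher number from compound 1 to compound 3 (0.89 log units; beyond the scatter), alongside an at least 7.9-fold higher number from compound 1 to compound 2 (0.89 log units; beyond the scatter), while a step that the two limits leave unreadable from compound 2 to compound 3 adds nothing. Going by these compounds, compound 4 resembles compound 1 in having neither 2-chlorophenyl nor 2-bromophenyl, so a move back toward a lower number is expected, although a methyl group is untested here. The expected size is an at least 4.7-fold lower number from compound 3 to compound 4 (0.67 log units; beyond the scatter), an estimate that rests on this single comparison. The estimate for compound 4 is 35000 nM, with an expected range of 12000 nM to 130000 nM.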

Compound 4, half-maximal inhibitory concentration: > 166000 nM
Compound 4 was reported as a limit (the forecaster's own chance of this, stated with the estimate: 30%); at least 4.7-fold (0.67 log units) between middle value and limit.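

Methyl in place of fluoro on an aromatic carbon gives an at least 7.9-fold higher number from compound 1 to compound 4 (0.89 log units; beyond the scatter), so in this assay the loss of a readable number is no longer tied to 2-chlorophenyl or 2-bromophenyl, since 4-methylphenyl ends at the same limit. The steps among compound 2, compound 3 and compound 4 cannot be read: both sides of each are limits. The series now rests on a single number, that of compound 1, with everything else at a limit: the limit of > 166000 nM in this assay, at which 3 of the 4 values shown sit.

Going by these compounds, whether that number depends on the fluoro itself or would hold for other groups on that aromatic carbon stays open. On these data alone, an unsubstituted phenyl, 4-chlorophenyl or 4-methoxyphenyl on the same saturated chain carbon would bear on this, and how far compound 2, compound 3 and compound 4 lie beyond the limit also remains unknown.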